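Removing the three fluorines from the anilino group

The compounds below may be only part of what the source reports. "The series", "measured", "known", "first", "only" and "open" are said of these compounds alone.

Three measured analogues share one core. Compound 1 `COc1ccc(Nc2ncnc3cc(OC)c(OCCCCC(=O)Nc4ccc(S(N)(=O)=O)cc4)cc23)cc1OC` gives 35400 nM in a functional assay on A-431 cells (Homo sapiens) for antiproliferative activity, read by MTT assay, with a stated time of 72 h; a higher number here means a weaker inhibitor, a lower number a stronger inhibitor; compound 2 `COc1cc2ncnc(Nc3ccc(OC(F)(F)F)cc3)c2cc1OCCCCC(=O)Nc1ccc(S(N)(=O)=O)cc1` gives 22500 nM in this assay; and compound 3 `COc1cc2ncnc(Nc3cc(F)c(F)c(F)c3)c2cc1OCCCCC(=O)Nc1ccc(S(N)(=O)=O)cc1` gives 23400 nM in this assay. On the numbers shown, compound 3 stands second highest of the three, with compound 2 nearest and compound 1 furthest, both gaps within the scatter. Compound 4 `COc1cc2ncnc(Nc3ccccc3)c2cc1OCCCCC(=O)Nc1ccc(S(N)(=O)=O)cc1` differs from compound 3 by phenyl in place of 3,4,5-trifluorophenyl on a nitrogen on an aromatic ring. For the measured compounds named here, the steps that bear on this change, all at that same nitrogen, were a 1.6-fold lower number from compound 1 to compound 2 (0.20 log units; within the scatter), a 1.5-fold lower number from compound 1 to compound 3 (0.18 log units; within the scatter) and a 1.0-fold higher number from compound 2 to compound 3 (0.02 log units; within the scatter), none beyond the scatter. Compound 4 is therefore expected to show no step beyond the scatter, a 1.1-fold higher number from compound 3 to compound 4 (0.03 log units; within the scatter). Compound 4 is estimated at 25000 nM in this assay, within a range from 10000 nM to 60000 nM.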

Compound 4, half-maximal inhibitory concentration: 25200 nM
Compound 4: middle estimate off by 1.0-fold (0.00 log units), on the low side, and the stated range covers the measured number.
By their numbers in this assay, from the lowest: compounds 2, 3, 4 and 1 (each within the scatter of the next).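

In this assay the unsubstituted anilino group stands level with all three substituted ones: the three fluorines can go (a 1.1-fold higher number from compound 3 to compound 4 (0.03 log units; within the scatter)), trifluoromethoxy can give way to hydrogen (a 1.1-fold higher number from compound 2 to compound 4 (0.05 log units; within the scatter)), and 3,4-dimethoxyphenyl can give way to phenyl (a 1.4-fold lower number from compound 1 to compound 4 (0.15 log units; within the scatter)). Compound 4 thus adds the bare ring as a reference point, and none of the substituents shown separates from it.

Going by these compounds, whether an amine or a carboxylic acid on this ring would move the number beyond the scatter stays open. No data here account for the flat numbers across these four compounds.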